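Dichloroaryl carbonyl variants on a shared pyridylmethylamine core

A few compounds are considered here, and "the series" means these few. Any claim that something is new, unique, unknown or untested is made for them only; others in the source may bear on it.

Measured compounds
compound 1 `Cc1cc(CNc2nc3cc(Cl)c(Cl)cc3[nH]2)ncc1-c1cn(C)nc1C`: 0.43 nM
compound 2 `Cc1cc(CNC(=O)c2cc(Cl)nc(Cl)c2)ncc1-c1cn(C)nc1C`: > 100 nM

Of the compounds shown here, two have been read in a functional assay on HFL1 cells for antagonist activity at sphingosine 1-phosphate receptor 2 (Homo sapiens), read by ELISA, with a stated time of 24 h, in the absence of a further agent; a higher number here means a weaker inhibitor, a lower number a stronger inhibitor. Compound 1 `Cc1cc(CNc2nc3cc(Cl)c(Cl)cc3[nH]2)ncc1-c1cn(C)nc1C` gives 0.43 nM in this assay. Compound 2 `Cc1cc(CNC(=O)c2cc(Cl)nc(Cl)c2)ncc1-c1cn(C)nc1C` returns only a limit in this assay, > 100 nM, so no number is known for it. This is the limit at which one of the two values sits (the limit of > 100 nM in this assay, at which 1 of the 2 values shown sits); compound 2 stands at the weak end of what has been measured, and the gap to compound 1 cannot be sized.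

Compound 3 `Cc1cc(CNC(=O)Nc2cc(Cl)cc(Cl)c2)ncc1-c1cn(C)nc1C` is not yet measured. It differs from compound 2 in one place (3,5-dichlorophenyl)amino in place of 2,6-dichloropyridin-4-yl on a carbonyl carbon, giving a urea in place of the amide. Compound 2 itself rests only on a limit, so the step can be judged only against that limit. For compound 3 a move toward stronger inhibition, beyond the scatter, is expected an at least 2.0-fold lower number from compound 2 to compound 3 (0.30 log units; that floor lies within the scatter), though a second limit remains possible. The estimate for compound 3 in this assay is 50 nM, between 5 nM and 300 nM.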

Compound 3, half-maximal inhibitory concentration: 0.3 nM
For compound 3 the middle estimate is 170-fold (2.22 log units) above the measured one; measured number below the stated range.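

In this assay the carbonyl carbon of this series tolerates far more than compound 2 suggested: with (3,5-dichlorophenyl)amino on that carbon, compound 3 gives 0.3 nM, so a urea on the shared core returns a real number rather than a limit. The change reads as an at least 330-fold lower number from compound 2 to compound 3 (2.52 log units; beyond the scatter), and this size is only a floor, since one end of the step is a limit: the limit of > 100 nM in this assay, at which 1 of the 3 values shown sits. A single change at this place is therefore enough to carry the series from the weak end of the measured range to a sub-nanomolar reading, far beyond the usual scatter.

The change replaces the ring and adds the amino nitrogen with its hydrogen-bond donor in one move, so the compounds shown cannot assign the gain to either part. A (2,6-dichloropyridin-4-yl)amino group on the same carbonyl carbon would separate the two, as would a methylene in place of the amino nitrogen of compound 3.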